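A few compounds are considered here, and "the series" means these few. Any claim that something is new, unique, unknown or untested is made for them only; others in the source may bear on it.

Series notes. In an assay on PC-12 cells for displacement of a labelled ligand from vesicular acetylcholine transporter (Homo sapiens) (a lower number here means a stronger inhibitor, a higher number a weaker inhibitor), compound 2 `OC1CCNCC1N1CCN(c2ccccc2)CC1` gives only a limit, > 100 nM. Compound 1 `OC1CN(Cc2ccc(Br)cc2)CCC1N1CCN(c2ccccc2)CC1`, the 4-bromobenzyl analogue, also gives only a limit in this assay, > 100 nM. Among the compounds with values here, both measured values rest at the limit of > 100 nM in this assay, at which 2 of the 2 values shown sit, so no step between measured compounds can be read. Compound 3 `OC1CCN(Cc2cccc(Br)c2)CC1N1CCN(c2ccccc2)CC1` is not yet measured; it differs from compound 2 by 3-bromobenzyl in place of hydrogen on an amine nitrogen in a ring. Compound 1 and compound 2 both sit at the limit of > 100 nM in this assay, at which 2 of the 2 values shown sit. The step that the limit leaves unreadable from compound 2 to compound 3 is expected to be none beyond the scatter, most likely ending in a limit again. Compound 3 is estimated at 300 nM, within 80 nM to 2000 nM.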

Compound 3, half-maximal inhibitory concentration: 46 nM
Compound 3: middle estimate off by 6.5-fold (0.81 log units), on the high side; the measured number lies below the stated range.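

The ring amine nitrogen tolerates a large group: with 3-bromobenzyl there, this assay gives a readable number, with an at least 2.1-fold lower number from compound 2 to compound 3 (0.33 log units; beyond the scatter). As far as these compounds go, the full size of this step stays unknown because compound 2 gives only a limit: the limit of > 100 nM in this assay, at which 2 of the 3 values shown sit. Within the data shown here, compound 1, with 4-bromobenzyl, also gives only a limit, > 100 nM, and it differs from compound 3 in more than one place, so no step between them can be read.

From the compounds shown here alone, whether the bromine matters remains open, as a plain benzyl or 3-chlorobenzyl on this nitrogen would show. Also open, going by these compounds, is whether a small group such as methyl there carries any of the step.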